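Swapping methoxy for fluoro on the aryl sulfide

The source may hold more compounds than are shown below. What is called first, only, known or untested is meant among the compounds shown, and "the series" means these compounds.

Compound 1 `Nc1cc(N)c2nc(-c3ccccc3)c(Oc3ccc(Cl)c(Cl)c3)nc2c1`: 91200 nM
Compound 2 `COc1ccc(Sc2nc3cc(N)cc(N)c3nc2-c2ccccc2)cc1`: < 100000 nM

The two measured compounds share one core and differ only in the group attached to one aromatic carbon. In a functional assay on IGROV-1 cells (Homo sapiens) for inhibition, read by sulforhodamine B assay, with a stated time of 48 h (a lower number here means that less compound is tolerated, a higher number that more compound is tolerated), compound 1 gives 91200 nM. For compound 2 this assay reports only a limit, < 100000 nM, not a number. The step that the limit leaves unreadable from compound 1 to compound 2 cannot be sized because the limit of < 100000 nM in this assay, at which 1 of the 2 values shown sits, leaves compound 2 without a number.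

Compound 3 `Nc1cc(N)c2nc(-c3ccccc3)c(Sc3ccc(F)cc3)nc2c1` keeps the sulfanyl link of compound 2 and changes only the group para to a large group: fluoro in place of methoxy on an aromatic carbon. No measured step bears on this change, and the one step shown is unreadable, so nothing here argues for a shift beyond the scatter. Compound 3 is therefore expected near the level of compound 1, estimated at 80000 nM with a range of 30000 nM to 100000 nM. The step this estimate implies is expected to be a step that the limit leaves unreadable from compound 2 to compound 3.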

Compound 3, concentration lethal to 50% of the cells: < 100000 nM
Compound 3: a limit, no number; the forecaster's own chance of this, stated with the estimate: 35%; the middle value does not contradict the limit.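

Neither step to compound 3, from compound 1 or from compound 2, can be read, because compound 3, like compound 2, has only a limit and no number: the limit of < 100000 nM in this assay, at which 2 of the 3 values shown sit.

The compounds shown leave open whether fluoro in place of methoxy changes the lethal concentration at all, and whether compound 2 or compound 3 differs from compound 1.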